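The source may hold more compounds than are shown below. What is called first, only, known or untested is meant among the compounds shown, and "the series" means these compounds.

In a functional assay on HepG2 cells (Homo sapiens) for antiproliferative activity, read by MTT assay, with a stated time of 72 h (on this read-out lower numbers stand for stronger inhibition and higher numbers for weaker inhibition), the measured compounds stand as follows:

compound 1, `O=c1nc2oc(C3CC3)c(C#CC3CC3)c2cn1Cc1cn(-c2ccccc2F)nn1`: 39100 nM
compound 2, `O=c1nc2oc(CCCCl)cc2cn1Cc1cn(-c2ccccc2F)nn1`: 79800 nM
compound 3, `O=c1c(I)cn(Cc2cn(Cc3ccccc3)nn2)c(=O)n1Cc1cn(Cc2ccccc2)nn1`: 5770 nM

Compound 1 gives the second highest of these three numbers. Its nearest neighbour is compound 2, whose number is higher by a gap beyond the scatter, while compound 3 stands furthest away, with a number lower than that of compound 1 by a gap also beyond the scatter. None of these pairs is a single-point step, so the three values show only where each compound falls.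

Compound 4, `O=c1nc2oc(C3CC3)c(C#CC3CC3)c2cn1Cc1cn(-c2ccc(Cl)cc2)nn1`, is not yet measured in this assay. It differs from compound 1 in one place: 4-chlorophenyl in place of 2-fluorophenyl on an aromatic nitrogen. Within the data shown here, no measured pair shows what such a swap does on this core, so the expectation rests on compound 1 alone. The step from compound 1 to compound 4 is expected to be small, at most a modest lowering, and likely within the scatter: a 1.3-fold lower number from compound 1 to compound 4 (0.12 log units; within the scatter). Compound 4 is therefore estimated at 30000 nM, within a range from 10000 nM to 90000 nM.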

Compound 4, half-maximal inhibitory concentration: 39200 nM
Beside the measured number, compound 4's estimate is 1.3-fold (0.12 log units) below it; low and high end bracket the measured number.
By their numbers in this assay, from the lowest: compound 3; then compounds 1 and 4 (each within the scatter of the next); then compound 2.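

The first single-place step among these compounds, in this assay, is a 1.0-fold higher number from compound 1 to compound 4 (0.00 log units; within the scatter), so 4-chlorophenyl and 2-fluorophenyl on this aromatic nitrogen cannot be told apart on the core of compound 1. The swap replaces fluorine with chlorine and also alters where the halogen sits on the phenyl ring, yet the two compounds remain within the scatter of each other. No measurement at hand explains this result.

Because both halogen identity and its place differ in this single pair, the compounds shown cannot say whether either alteration alone would leave the number undisturbed, as 4-fluorophenyl or 2-chlorophenyl might show. On these data alone, it also remains open whether a phenyl ring carrying a carboxylic acid or an amine, or a longer alkyl chain in place of the phenyl, would stand apart from these two compounds.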